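Swapping the alkyne aryl group from pyrimidine to furan

A few compounds are considered here, and "the series" means these few. Any claim that something is new, unique, unknown or untested is made for them only; others in the source may bear on it.

Among the compounds with values here, in an assay on CHO cells for displacement of a labelled ligand from adenosine receptor A3 (Homo sapiens), read by scintillation counting, with a stated time of 60 min (on this read-out higher numbers stand for weaker inhibition and lower numbers for stronger inhibition), compound 2 `CNC(=O)[C@@]12C[C@@H]1[C@@H](n1cnc3c(NC)nc(C#Cc4ncccn4)nc31)[C@H](O)[C@@H]2O` gives 1.97 nM, the lower of the two numbers so far, while compound 1 `CNC(=O)[C@@]12C[C@@H]1[C@@H](n1cnc3c(NC)nc(C#Cc4cccc(C(F)(F)F)c4)nc31)[C@H](O)[C@@H]2O` gives 3.39 nM in this assay ; the difference a 1.7-fold lower number from compound 1 to compound 2 (0.24 log units; within the scatter) lies within the scatter. Compound 3 `CCc1ccc(C#Cc2nc(NC)c3ncn([C@H]4[C@H](O)[C@H](O)[C@]5(C(=O)NC)C[C@H]45)c3n2)o1` carries the change (5-ethylfuran-2-yl in place of pyrimidin-2-yl on a triple-bonded carbon). Within the data shown here, the only measured step at this position, a 1.7-fold lower number from compound 1 to compound 2 (0.24 log units; within the scatter), was within the scatter, so another aryl swap on the triple-bonded carbon is expected to give a step of a 1.5-fold higher number from compound 2 to compound 3 (0.18 log units; within the scatter), no larger than the scatter. Compound 3 is therefore estimated at 3 nM in this assay , with a range from 1 nM to 10 nM.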

Compound 3, inhibition constant: 1.5 nM
The estimate for compound 3 lay 2.0-fold (0.30 log units) above the measured number, within the range that was stated.
By their numbers in this assay, from the lowest: compounds 3, 2 and 1 (each within the scatter of the next, the first and the last beyond it).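

In this assay, 5-ethylfuran-2-yl on the triple-bonded carbon matches pyrimidin-2-yl within the scatter, a 1.3-fold lower number from compound 2 to compound 3 (0.12 log units; within the scatter), although a five-membered aromatic ring with one hetero atom replaces a six-membered one with two. Against 3-(trifluoromethyl)phenyl, the position now gives its first step beyond the scatter, though a modest one, a 2.3-fold lower number from compound 1 to compound 3 (0.35 log units; beyond the scatter). Nothing available here accounts for these numbers. The compounds shown leave open whether the ethyl group contributes, as plain furan-2-yl would show. They also leave open whether an aromatic ring is needed here at all, as an aminomethyl group or a longer alkyl chain on the triple-bonded carbon would show.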